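The source may hold more compounds than are shown below. What is called first, only, known or untested is meant among the compounds shown, and "the series" means these compounds.

Working notes on the series.

Compound 1 `COc1ccc(/C=C/C(=O)CC(C)=O)cc1` in a functional assay on HCT-116 cells (Homo sapiens) for cytotoxicity, read by MTT assay, with a stated time of 72 h (a higher number here means a weaker inhibitor, a lower number a stronger inhibitor), gives 11900 nM. Compound 2 `COc1ccc(/C=C/c2cc(C)no2)cc1` in this assay gives 22400 nM, a reading that lies within the scatter of compound 1. Compound 3 `Cc1cc(/C=C/c2ccc(O)cc2)on1` in this assay gives 67900 nM. Among the compounds with values here, the one matched pair so far is compound 2 to compound 3, (hydrogen in place of methyl on an oxygen on an aromatic ring), which gives a 3.0-fold higher number from compound 2 to compound 3 (0.48 log units; beyond the scatter). The difference between the core of compound 1 and the core of compound 2 is not broken down here.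

Compound 4 `CC(=O)CC(=O)/C=C/c1ccc(O)cc1` is not yet measured in this assay. It carries the same change against compound 1 as compound 3 carries against compound 2: hydrogen in place of methyl on an oxygen on an aromatic ring, at a place described in the same words. Within the data shown here, the expectation is that compound 4 follows the one precedent, with an estimated step of a 2.7-fold higher number from compound 1 to compound 4 (0.43 log units; beyond the scatter), resting on a 3.0-fold higher number from compound 2 to compound 3 (0.48 log units; beyond the scatter); a single precedent on a different core leaves the size loosely fixed. Compound 4 is thus expected to give about 32000 nM in this assay, estimated between 12000 nM and 85000 nM.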

Compound 4, half-maximal inhibitory concentration: 36500 nM
For compound 4 the middle estimate is 1.1-fold (0.06 log units) below the measured one; the measured number falls inside the stated range.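

Methoxy to hydroxy on the core of compound 1 gives a 3.1-fold higher number from compound 1 to compound 4 (0.49 log units; beyond the scatter) in this assay. Set beside the earlier step, the same change carries over between the two cores with no difference in size beyond the scatter: the same change on two cores in this assay, a 3.0-fold higher number (0.48 log units; beyond the scatter) from compound 2 to compound 3 and a 3.1-fold higher number (0.49 log units; beyond the scatter) from compound 1 to compound 4, 1.0-fold (0.01 log units) apart, within the scatter of two such steps. This shows that the step held its size on these two cores in this one cell assay, but two cores are a narrow base: it does not show that the step would hold on any other core, and it gives no reason why the hydroxy compounds read higher.

The compounds shown leave open whether a different group in place of the methoxy, such as an ethoxy, a longer alkoxy chain or an amine, would move the number in the same way. They also leave open which part of the difference between the two cores matters for the reading, since that difference is not broken down into single changes.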